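This account rests on a few compounds, and the source may have more. Where it says the series, first, only, none or still open, it means among the compounds named here.

Compound 3 `Cc1cc(Nc2cccc(S(F)(F)(F)(F)F)c2)nc(N)n1` stands only at the limit of an assay on cells for inhibition of S-adenosylmethionine decarboxylase proenzyme (Homo sapiens), read by mass spectrometry, at pH 7.2; a lower number here means a stronger inhibitor, a higher number a weaker inhibitor: there compound 3 gives > 180000 nM, a limit rather than a number. Compound 1 `Cc1cc(Nc2cc(Br)cc(S(F)(F)(F)(F)F)c2)nc(N)n1` likewise gives > 180000 nM, also a limit (the limit of > 180000 nM in this assay, at which 2 of the 3 values shown sit). Compound 2 `Cc1cc(Nc2cc(Br)cc(OCC(F)(F)F)c2)nc(N)n1` gives 44000 nM. Compound 4 `Cc1cc(Nc2cccc(Br)c2)nc(N)n1` differs from compound 3 by one bromine atom in place of a group of 6 heavy atoms (5 fluorine, 1 sulfur; no ring), on an aromatic carbon. The step that the two limits leave unreadable from compound 1 to compound 3 does not settle where compound 3 lies. The step of an at least 4.0-fold lower number from compound 1 to compound 2 (0.61 log units; beyond the scatter) is the one that bears on the change here, for in it too the same group of 6 heavy atoms leaves and the number falls. A lower number is therefore expected, a step of an at least 3.0-fold lower number from compound 3 to compound 4 (0.47 log units; beyond the scatter), though a further limit remains possible. Compound 4 is estimated at 60000 nM, between 15000 nM and 180000 nM.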

Compound 4, half-maximal inhibitory concentration: > 180000 nM
Compound 4 gave a limit, no number; the forecaster's own chance of this, stated with the estimate: 35%; middle value at least 3.0-fold (0.47 log units) away from the limit.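

In this assay there is an at least 4.0-fold higher number from compound 2 to compound 4 (0.61 log units; beyond the scatter), so with hydrogen in place of 2,2,2-trifluoroethoxy, the bromo group alone does not keep a readable number. Bromo in place of the group of 6 heavy atoms also brings no readable gain, unlike the 2,2,2-trifluoroethoxy group. The steps among compounds 1, 3 and 4 cannot be read, for each of these compounds gives only a limit: the limit of > 180000 nM in this assay, at which 3 of the 4 values shown sit.

Going by these compounds, how far these three compounds lie from one another stays open. So does whether a methoxy group or an amine in place of 2,2,2-trifluoroethoxy would keep a readable number.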